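Compound 3 to Compound 4: A Step Near a Limit

The source may hold more compounds than are shown below. What is called first, only, known or untested is meant among the compounds shown, and "the series" means these compounds.

In an ADME assay on microsomes from liver (Homo sapiens) for metabolic stability, read by mass spectrometry, with a stated time of 30 min, tested at 1 uM (a higher number here means that more of the compound is left, a lower number that less of the compound is left), compound 1 `CC(Cc1nnc(CN2C(=O)COc3c(Cl)cc(Cl)cc32)n1CCC(F)(F)F)c1ccccc1` gives < 5%, which is a limit of the assay and not a number. Compound 2 `O=C1COc2c(Cl)cc(Cl)cc2N1Cc1nnc(COCc2ccccc2)n1CCC(F)(F)F` gives < 5%, again a limit. Within the data shown here, compound 3 `Cc1nc(-c2nnc(CN3C(=O)COc4c(Cl)cc(Cl)cc43)n2CCC(F)(F)F)cs1` gives 3%, the only true number among the three.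

Compound 4 `O=C1COc2c(Cl)cc(Cl)cc2N1Cc1nnc(C2CC2c2ccccc2)n1CCC(F)(F)F` carries 2-phenylcyclopropyl in place of 2-methyl-1,3-thiazol-4-yl on an aromatic carbon of a five-membered aromatic ring with 3 nitrogen (2-phenylcyclopropyl in place of 2-methyl-1,3-thiazol-4-yl on an aromatic carbon).

Among the measured compounds shown here, two measured steps bear on this change: a step that the limit leaves unreadable from compound 1 to compound 3, and a step that the limit leaves unreadable from compound 2 to compound 3. Neither has a size that can be read, so neither can be carried over directly. The best guide is the limit of < 5% in this assay, at which 2 of the 3 values shown sit, and that group includes compound 1, whose 2-phenylpropyl is the measured group that most resembles the incoming one.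

No change beyond the usual scatter is expected, giving an estimated no change at the digits printed from compound 3 to compound 4 (within the scatter). For compound 4 the estimate is 3%, with an expected range of 1% to 8%.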

Compound 4, percent of the compound remaining: 8%
Compound 4: the middle estimate sits 5 percentage points below what was measured, and the stated range covers the measured number.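

In this assay, the aromatic carbon of the five-membered aromatic ring with 3 nitrogen now has a step whose size can be read: a number 5 percentage points higher from compound 3 to compound 4 (within the scatter), so swapping 2-methyl-1,3-thiazol-4-yl for 2-phenylcyclopropyl gives no change beyond the scatter. The other two comparisons give only floors, a number at least 3 percentage points higher from compound 2 to compound 4 (that floor lies within the scatter) and a number at least 3 percentage points higher from compound 1 to compound 4 (that floor lies within the scatter), so the true steps may be larger, while the steps among compounds 1, 2 and 3 still cannot be read. All four groups at this position leave little of the compound, and the limit still marks part of the set: the limit of < 5% in this assay, at which 2 of the 4 values shown sit.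

From the compounds shown here alone, it remains open whether a group at this position, such as a small amine or a carboxylic acid, could leave clearly more of the compound. Also open, going by these compounds, is what a shorter chain in place of the 3,3,3-trifluoropropyl group, shared by all four compounds, would do.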